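The source may hold more compounds than are shown below. What is called first, only, known or untested is meant among the compounds shown, and "the series" means these compounds.

Measured in an ADME assay on liver (Mesocricetus auratus) for metabolic stability, using microsomes; a lower number here means slower removal, a higher number faster removal of the compound:
- compound 1 `O=C(NCc1ccccc1)Nc1[nH]nc(-c2ccccn2)c1Cl`: > 400 mL.min-1.g-1 (a limit of the assay)
- compound 2 `N#Cc1ccc(C2CCN(C(=O)Nc3cc(-c4ccccn4)n[nH]3)CC2)cc1`: 80.8 mL.min-1.g-1
- compound 3 `COc1ccccc1C(=O)Nc1[nH]nc(-c2ccccn2)c1C1CC1`: > 100 mL.min-1.g-1 (a limit of the assay)

Compound 2 is the only one of the three with an actual number, which makes it the single firm reference point. Compound 1 is known only as a limit. Compound 3 is likewise known only as a limit.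

Compound 4 `O=C(Nc1cc(-c2ccccn2)n[nH]1)N1CCC(c2cccc(Cl)c2)CC1` keeps the rest of compound 2 and changes one group: 3-chlorophenyl in place of 4-cyanophenyl on a saturated ring carbon. In words, this is 3-chlorophenyl in place of 4-cyanophenyl on a saturated ring carbon. Going by the values given here, no step between measured compounds is available to size this change. The expectation therefore starts from compound 2 at 80.8 mL.min-1.g-1. The two limits offer only a loose hint towards the upper side. The estimated step of a 1.6-fold higher number from compound 2 to compound 4 (0.21 log units; within the scatter) is an upward move of modest size, expected to stay within the usual scatter. In this assay the estimate for compound 4 is 130 mL.min-1.g-1, expected to fall between 55 mL.min-1.g-1 and 320 mL.min-1.g-1.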

Compound 4, intrinsic clearance in microsomes: 63.5 mL.min-1.g-1
Compound 4: the middle estimate sits 2.0-fold (0.31 log units) above what was measured, within the range that was stated.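

In this assay, going by these compounds alone, putting 3-chlorophenyl in place of 4-cyanophenyl on a saturated ring carbon gives a 1.3-fold lower number from compound 2 to compound 4 (0.10 log units; within the scatter) and provides the first comparison of compounds that differ in one place. Compound 2 and compound 4 therefore cannot be told apart in this assay, even though the nitrile leaves and a chlorine enters on a phenyl ring at a different ring position. Nothing shown here accounts for this result.

Going by these compounds, it remains open whether an amine or a carboxylic acid on that saturated ring carbon, in place of these substituted phenyl groups, would produce a step beyond the scatter. Compound 1 and compound 3 differ from compound 2 in more than one place, so they cannot settle this question.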